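This account rests on a few compounds, and the source may have more. Where it says the series, first, only, none or still open, it means among the compounds named here.

Two compounds of this series have numbers in a functional assay on OE19 cells (Homo sapiens) for cytotoxicity, read by MTT assay, with a stated time of 48 h; on this read-out higher numbers stand for weaker inhibition and lower numbers for stronger inhibition. Compound 1 `CC1(C)S[C@@H]2/C(=C\C(=O)OC(c3ccccc3)c3ccccc3)C(=O)N2[C@H]1C(=O)OC(c1ccccc1)c1ccccc1` gives 21600 nM in this assay. Compound 2 `CC1(C)S[C@@H]2/C(=C\C(=O)c3ccc(F)cc3)C(=O)N2[C@H]1C(=O)OC(c1ccccc1)c1ccccc1` gives 12100 nM in this assay, and the two numbers lie within the scatter of each other, so neither compound is set apart.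

Compound 3 `CC1(C)S[C@@H]2/C(=C\C(=O)OCc3ccccc3)C(=O)N2[C@H]1C(=O)OC(c1ccccc1)c1ccccc1` has not been measured. It differs from compound 2 in one place: benzyloxy in place of 4-fluorophenyl on a carbonyl carbon. For the measured compounds named here, only compound 1 shows an ester at this carbonyl, and no step between two measured compounds isolates this change, so nothing beyond the scatter is expected from compound 2 to compound 3, giving an expected 1.5-fold higher number from compound 2 to compound 3 (0.17 log units; within the scatter). For compound 3 the estimate is 18000 nM, with a range from 7000 nM to 45000 nM.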

Compound 3, half-maximal inhibitory concentration: 8200 nM
Beside the measured number, compound 3's estimate is 2.2-fold (0.34 log units) above it, and the stated range covers the measured number.
By their numbers in this assay, from the lowest: compounds 3, 2 and 1 (each within the scatter of the next, the first and the last beyond it).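

In this assay the carbonyl carbon carries benzyloxy in place of 4-fluorophenyl with a 1.5-fold lower number from compound 2 to compound 3 (0.17 log units; within the scatter) and no departure from the scatter. Among the esters at this carbonyl, hydrogen in place of phenyl on the saturated chain carbon gives a 2.6-fold lower number from compound 1 to compound 3 (0.42 log units; beyond the scatter) as the first step in the series beyond the scatter, though a modest one. Nothing available here bears on the reason for either step. As far as these compounds go, whether an amine on this carbonyl carbon or a longer chain in place of benzyloxy would move the number stays open.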